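Cyclohexylamino Replaces Pyrrolidinyl on the Shared Core

A few compounds are considered here, and "the series" means these few. Any claim that something is new, unique, unknown or untested is made for them only; others in the source may bear on it.

Compound 1 `O=C1C(N2CCCC2)=CC(=O)c2c1nc1n2[C@H]2OC[C@@H](O)[C@H]2OC1` carries a pyrrolidin-1-yl group on a double-bonded ring carbon of the shared core. In a functional assay on HeLa cells (Homo sapiens) for inhibition, read by sulforhodamine B assay (on this read-out lower numbers stand for stronger inhibition and higher numbers for weaker inhibition), compound 1 gives only a limit, > 16000 nM. This is the limit of > 16000 nM in this assay, at which 2 of the 3 values shown sit, so compound 1 stands among the weakest values recorded. Compound 2 `O=C1C=C(Nc2ccc(Br)cc2)C(=O)c2c1nc1n2[C@H]2OC[C@@H](O)[C@H]2OC1` bears a (4-bromophenyl)amino group in that place, and in this assay compound 2 gives 3830 nM. Compound 3 `CCCN(CCC)C1=CC(=O)c2nc3n(c2C1=O)[C@H]1OC[C@@H](O)[C@H]1OC3` carries a dipropylamino group. In this assay compound 3 gives only a limit, > 16000 nM. Within the data shown here, the single step measured in one place is an at least 4.1-fold higher number from compound 2 to compound 3 (0.62 log units; beyond the scatter): exchanging the amino group that carries a hydrogen-bond donor for one that does not weakened the inhibition.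

Compound 4 `O=C1C(NC2CCCCC2)=CC(=O)c2c1nc1n2[C@H]2OC[C@@H](O)[C@H]2OC1` has not yet been measured. It differs from compound 1 by cyclohexylamino in place of pyrrolidin-1-yl on a double-bonded ring carbon. Read in reverse, the step from compound 2 to compound 3 suggests that bringing in a hydrogen-bond donor at this position should strengthen inhibition, though cyclohexylamino is not (4-bromophenyl)amino, so only part of that gain is expected. Compound 4 is therefore expected to give about 7000 nM in this assay, within 2500 nM to 16000 nM. That estimate means a step of an at least 2.2-fold lower number from compound 1 to compound 4 (0.35 log units; beyond the scatter), expected to carry compound 4 off the limit.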

Compound 4, half-maximal inhibitory concentration: > 16000 nM
Compound 4: no number, only a limit; the forecaster's own chance of this, stated with the estimate: 35%; at least 2.2-fold (0.35 log units) between middle value and limit.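

Compound 4, like compound 1, gives only a limit in this assay, so the step between compound 1 and compound 4 cannot be read. The compounds shown leave open whether cyclohexylamino or pyrrolidin-1-yl goes with the stronger inhibition on the shared core.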